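Allyl diketopiperazine series: dichlorophenyl swap on the benzylidene arm

This account rests on a few compounds, and the source may have more. Where it says the series, first, only, none or still open, it means among the compounds named here.

Two compounds of the shared core have data. Compound 1 `COc1ccccc1/C=c1/[nH]c(=O)/c(=C\c2cccc(Cl)c2Cl)[nH]c1=O` gives "not active" (no number reported) in a functional assay on Huh-7 cells (Homo sapiens) for cytotoxicity, read by CCK-8 assay, with a stated time of 72 h; a higher number here means a weaker inhibitor, a lower number a stronger inhibitor. Among the measured compounds shown here, compound 2 `C=CCn1c(=O)/c(=C\c2cccc(F)c2)[nH]c(=O)/c1=C\c1ccccc1OC` gives 27200 nM in this assay, the only number measured so far, so it stands alone. Compound 3 `C=CCn1c(=O)/c(=C\c2ccc(Cl)c(Cl)c2)[nH]c(=O)/c1=C\c1ccccc1OC` is the next entry: it carries 3,4-dichlorophenyl in place of 3-fluorophenyl on a double-bonded chain carbon bound to an aromatic carbon. For the measured compounds named here, no step between measured compounds exists to anchor the change, and compound 1 offers no number to compare against. The step from compound 2 to compound 3 is expected to be small, within scatter, a 1.2-fold lower number from compound 2 to compound 3 (0.09 log units; within the scatter). Compound 3 is thus estimated at 22000 nM with a range of 8000 nM to 60000 nM in this assay.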

Compound 3, half-maximal inhibitory concentration: "not active" (no number reported)
Nothing numeric was reported for compound 3; there is nothing to compare the estimate with.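

Among the compounds shown here, compound 3 carries no number, so no step from compound 2 to compound 3 can be read. No further measurement bears on this result. The compounds shown leave open how far 3,4-dichlorophenyl in place of 3-fluorophenyl shifts cytotoxicity.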